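From carbamate to urea on a shared core

A few compounds are considered here, and "the series" means these few. Any claim that something is new, unique, unknown or untested is made for them only; others in the source may bear on it.

Measured so far:
compound 1 `COCCn1c(SCc2cc([N+](=O)[O-])ccc2OC)nc2cc(NC(=O)NC(C)(C)C)ccc21` — 57 nM
compound 2 `COc1ccc([N+](=O)[O-])cc1CSc1nc2cc(NC(=O)OC(C)(C)C)ccc2n1C(C)C` — 880 nM

Both compounds were tested in an assay on isolated protein for inhibition of Gonadotropin-releasing hormone receptor (Homo sapiens); a lower number here means a stronger inhibitor, a higher number a weaker inhibitor. Going by the values given here, of the two numbers, compound 2 stands highest, with compound 1 giving a number that is far lower, well beyond the scatter; the two structures differ in more than one place, so no single step links them.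

Compound 3 `COc1ccc([N+](=O)[O-])cc1CSc1nc2cc(NC(=O)NC(C)(C)C)ccc2n1C(C)C` is not yet measured. It keeps the core and the isopropyl group of compound 2 and changes only one thing: (tert-butyl)amino in place of tert-butoxy on a carbonyl carbon. The carbamate of compound 2 thereby becomes a urea, the same urea that compound 1 carries.

In this assay compound 3 is expected to give a lower number than compound 2, a sizeable step an 8.0-fold lower number from compound 2 to compound 3 (0.90 log units; beyond the scatter) beyond the scatter, because the urea-bearing compound 1 gives 57 nM. Compound 3 is therefore estimated at 110 nM, within a range of 30 nM to 400 nM.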

Compound 3, half-maximal inhibitory concentration: 62 nM
Compound 3: middle estimate off by 1.8-fold (0.25 log units), on the high side, and the stated range covers the measured number.
By their numbers in this assay, from the lowest: compounds 1 and 3 (each within the scatter of the next); then compound 2.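

In this assay the change from tert-butoxy to (tert-butyl)amino on the carbonyl carbon gives a 14-fold lower number from compound 2 to compound 3 (1.15 log units; beyond the scatter) on an otherwise unchanged structure. This shows that one swap, turning the carbamate into a urea, is enough for a large step, even though the group leaving and the group entering each hold 5 heavy atoms. With the urea in place, isopropyl in place of 2-methoxyethyl on the aromatic nitrogen gives a 1.1-fold higher number from compound 1 to compound 3 (0.04 log units; within the scatter) and so leaves the number effectively unchanged, and nothing available explains either result.

Going by these compounds, whether the urea's hydrogen matters remains open, and a urea with a methyl group on that nitrogen would test it. Also open, on these data alone, is how far the tert-butyl group can change, for example to a cyclopropyl or phenyl group, while the number stays this low.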